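The compounds below may be only part of what the source reports. "The series", "measured", "known", "first", "only" and "open" are said of these compounds alone.

The measured compounds:

Compound 1, `C=C1C[C@]23C[C@@]1(O)CC[C@H]2c1ccc(OS(=O)(=O)c2ccc(C)cc2)c(C)c1[C@@H]3Cn1cc(-c2ccc(Cl)cc2)nn1`. In a functional assay on A549 cells (Homo sapiens) for cytotoxicity, read by MTT assay, with a stated time of 4 days (on this read-out lower numbers stand for stronger inhibition and higher numbers for weaker inhibition), compound 1 gives > 20000 nM, which is a limit of the assay and not a number.

Compound 2, `C=C1C[C@]23C[C@@]1(O)CC[C@H]2c1ccc(OS(=O)(=O)c2ccc(C)cc2)c(C)c1[C@@H]3Cn1cc(-c2ccc(C)cc2)nn1`. In this assay compound 2 gives > 20000 nM, again a limit of the assay.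

Compound 3, `C=C1C(=O)[C@]23C[C@@]1(O)CC[C@H]2c1ccc(O)c(C)c1[C@@H]3Cn1cc(-c2ccc(Cl)cc2)nn1`. In this assay compound 3 gives 640 nM.

Compound 4, `C=C1C(=O)[C@]23C[C@@]1(O)CC[C@H]2c1ccc(O)c(C)c1[C@@H]3Cn1cc(-c2ccc(C)cc2)nn1`, has not yet been measured. It differs from compound 3 by methyl in place of chloro on an aromatic carbon. The same change separates compound 1 from compound 2, (methyl in place of chloro on an aromatic carbon), and in this assay it gave a step that the two limits leave unreadable from compound 1 to compound 2, because both values rest at the limit of > 20000 nM in this assay, at which 2 of the 3 values shown sit. The difference between the cores of compound 1 and compound 3 is not broken down here. Among the compounds with values here, the only readable anchor is compound 3 at 640 nM. For compound 4 the expected step is a 1.4-fold higher number from compound 3 to compound 4 (0.15 log units; within the scatter). Compound 4 is expected to give 900 nM, between 300 nM and 3000 nM.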

Compound 4, half-maximal inhibitory concentration: 1260 nM
Compound 4: middle estimate off by 1.4-fold (0.15 log units), on the low side; the range from low to high includes it.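

In this assay, the change from 4-chlorophenyl to 4-methylphenyl on the core of compound 3 gives a 2.0-fold higher number from compound 3 to compound 4 (0.29 log units; within the scatter). The same change on the core of compound 1 cannot be read, because compound 1 and compound 2 both give a limit of the assay and not a number: the limit of > 20000 nM in this assay, at which 2 of the 4 values shown sit. The change can therefore be sized on one core only, and the compounds shown do not tell whether its step carries over from one core to the other.

The compounds shown leave open what an amine, a carboxylic acid or a longer chain would give in place of the chloro or methyl group on the core of compound 3. They also leave open how the separate differences between the two cores bear on the read-out.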